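The source may hold more compounds than are shown below. What is called first, only, known or untested is meant among the compounds shown, and "the series" means these compounds.

Values in a functional assay on HCT-116 cells (Homo sapiens) for inhibition; on this read-out higher numbers stand for weaker inhibition and lower numbers for stronger inhibition:

- compound 1 `CC(C)=CCC/C(C)=C/C[C@]12C[C@@H](CC=C(C)C)C(C)(C)[C@](CC=C(C)C)(C(=O)C(C(=O)c3ccc(O)c(O)c3)=C1O)C2=O`: 8.6 ug/mL
- compound 3 `CC(C)=CC[C@@H]1C[C@]2(CC=C(C)C)C(=O)[C@@](CC=C(C)C)(C(=O)C(C(=O)c3ccc(O)c(O)c3)=C2O)C1(C)C`: 9.22 ug/mL
- compound 2 `CC(C)=CCC/C(C)=C/C[C@@H]1C[C@@]2(C/C=C(\C)CCC=C(C)C)C(=O)CC(=O)[C@](CC=C(C)C)(C2=O)C1(C)C`: > 20 ug/mL, a limit of the assay and not a number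

The change from compound 1 to compound 3 is hydrogen in place of 3-methylbut-2-en-1-yl on a saturated chain carbon bound to a double-bonded chain carbon. It gave a 1.1-fold higher number from compound 1 to compound 3 (0.03 log units; within the scatter). Compound 4 `CC(C)=CCC/C(C)=C/C[C@@H]1C[C@@]2(CC=C(C)C)C(=O)CC(=O)[C@](CC=C(C)C)(C2=O)C1(C)C` is not yet measured and stands to compound 2 as compound 3 stands to compound 1: hydrogen in place of 3-methylbut-2-en-1-yl on a saturated chain carbon bound to a double-bonded chain carbon. The place is the same word for word, so this is the same change. How the core of compound 2 differs from that of compound 1 is not broken down here. For compound 2 only the limit of > 20 ug/mL in this assay, at which 1 of the 3 values shown sits, is known. From compound 2 to compound 4 a step of about the earlier size is expected, a step that the limit leaves unreadable from compound 2 to compound 4, resting on compound 1 and compound 3 with a 1.1-fold higher number from compound 1 to compound 3 (0.03 log units; within the scatter). For compound 4 the estimate in this assay is 25 ug/mL, between 10 ug/mL and 60 ug/mL, and a limit again seems likely.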

Compound 4, half-maximal inhibitory concentration: 9.14 ug/mL
Compound 4: middle estimate off by 2.7-fold (0.44 log units), on the high side; measured number outside the range, below it.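

In this assay, hydrogen in place of 3-methylbut-2-en-1-yl gave an at least 2.1-fold lower number from compound 2 to compound 4 (0.34 log units; beyond the scatter). The value of compound 2, > 20 ug/mL, is a limit of the assay and not a number, so this step has a bound but no exact size. Set beside the earlier step, this does not show that the change carries over from one core to the other with a set size, nor that it behaves differently on the two cores: the same change on two cores in this assay, a 1.1-fold higher number (0.03 log units; within the scatter) from compound 1 to compound 3 and an at least 2.1-fold lower number (0.34 log units; beyond the scatter) from compound 2 to compound 4; the limit leaves it open whether they differ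

Still open, from the compounds shown here alone, is how either core responds to other groups at this place, on a saturated chain carbon bound to a double-bonded chain carbon. Examples would be a saturated pentyl chain, a longer chain, or a chain ending in an amine or a carboxylic acid.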